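Swapping the Arylpiperazine Headgroup on the Long-Chain Analogue

The compounds below may be only part of what the source reports. "The series", "measured", "known", "first", "only" and "open" are said of these compounds alone.

- Compound 1, `COc1ccccc1N1CCN(CCCCn2nc(-c3ccc(C)cc3)c3ccccc3c2=O)CC1`, gives 2.6 nM in an assay on Cerebral cortex for displacement of a labelled ligand from Adrenergic receptor alpha-1 (Rattus norvegicus); a higher number here means a weaker inhibitor, a lower number a stronger inhibitor.
- Compound 2, `CCOc1ccccc1N1CCN(CCCCn2nc(-c3ccc(C)cc3)c3ccccc3c2=O)CC1`, gives 2.23 nM in this assay.
- Compound 3, `COc1ccccc1N1CCN(CCCCCCCn2nc(-c3ccc(C)cc3)c3ccccc3c2=O)CC1`, gives 8.4 nM in this assay.

Compound 3 shows the highest of the three numbers in this assay, above both compound 1 and compound 2, and its gap to each lies beyond the scatter. Compound 4, `Cc1ccc(-c2nn(CCCCCCCN3CCN(c4cccc(C(F)(F)F)c4)CC3)c(=O)c3ccccc23)cc1`, differs from compound 3 by 3-(trifluoromethyl)phenyl in place of 2-methoxyphenyl on an amine nitrogen in a ring. Going by the values given here, the only measured step, a 1.2-fold lower number from compound 1 to compound 2 (0.07 log units; within the scatter), concerns the alkoxy chain on the aryl ring and does not cover replacing that ring altogether, so no measured step bears on this change. In the absence of such a precedent, compound 4 is expected to give a modestly higher number, estimated at 25 nM (range 8 nM to 80 nM), which would mean an expected step of a 3.0-fold higher number from compound 3 to compound 4 (0.47 log units; beyond the scatter).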

Compound 4, inhibition constant: 382 nM
The estimate for compound 4 lay 15-fold (1.18 log units) below the measured number; measured number above the stated range.
By their numbers in this assay, from the lowest: compounds 2 and 1 (each within the scatter of the next); then compound 3; then compound 4.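

Replacing the aryl group on the amine nitrogen in the ring proves far from neutral: 3-(trifluoromethyl)phenyl in place of 2-methoxyphenyl brings a 45-fold higher number from compound 3 to compound 4 (1.66 log units; beyond the scatter) in this assay. The earlier compounds had shown only a change within the alkoxy group, a 1.2-fold lower number from compound 1 to compound 2 (0.07 log units; within the scatter), and so gave no sign that this position could respond so strongly to a change of the whole aryl group. Nothing available explains the size of this step.

The change alters both the substituent and where it sits on the aryl ring, so the compounds shown do not separate these two parts. On these data alone, whether a plain phenyl group on that nitrogen would fall nearer compound 3 or compound 4 also remains open.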